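A Methoxy-to-Hydroxy Step Where Only Limits Are Known

This account rests on a few compounds, and the source may have more. Where it says the series, first, only, none or still open, it means among the compounds named here.

compound 1, `O=C(Nc1cccc(-n2cc(-c3ccncc3)c(-c3ccc(Cl)c(O)c3)n2)c1)Nc1cccc(C(F)(F)F)c1`: > 32500 nM
compound 2, `COc1cc(-c2nn(-c3cccc(NC(=O)Nc4ccc(Cl)c(Cl)c4)c3)cc2-c2ccncc2)ccc1Cl`: > 50000 nM

Compound 1 `O=C(Nc1cccc(-n2cc(-c3ccncc3)c(-c3ccc(Cl)c(O)c3)n2)c1)Nc1cccc(C(F)(F)F)c1` in a functional assay on SN12C cells (Homo sapiens) for inhibition, read by sulforhodamine B assay, with a stated time of 48 h (on this read-out lower numbers stand for stronger inhibition of growth and higher numbers for weaker inhibition of growth), gives > 32500 nM; this is a limit of the assay, not a number. Compound 2 `COc1cc(-c2nn(-c3cccc(NC(=O)Nc4ccc(Cl)c(Cl)c4)c3)cc2-c2ccncc2)ccc1Cl` gives > 50000 nM in this assay, and this too is a limit rather than a number. Compound 2 therefore stands nowhere on a scale of numbers: it sits at the limit of > 50000 nM in this assay, at which 1 of the 2 values shown sits, while the only other value shown sits at the limit of > 32500 nM in this assay, at which 1 of the 2 values shown sits, so both compounds have shown no growth inhibition within the tested range.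

Compound 3 `O=C(Nc1cccc(-n2cc(-c3ccncc3)c(-c3ccc(Cl)c(O)c3)n2)c1)Nc1ccc(Cl)c(Cl)c1` differs from compound 2 by hydrogen in place of methyl on an oxygen on an aromatic ring. Among the compounds with values here, no step between two measured compounds describes this change, and the one other hydroxy compound, compound 1, also gave only a limit. The step in this assay from compound 2 to compound 3 is expected to be none beyond the scatter, a number no higher from compound 2 to compound 3 (the limit leaves the size open), and most likely to end again at a limit. Compound 3 is thus estimated at 50000 nM, within 15000 nM to 150000 nM.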

Compound 3, concentration for total growth inhibition: > 32500 nM
Compound 3 gave a limit, no number (the forecaster's own chance of this, stated with the estimate: 80%); the middle value does not contradict the limit.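

In this assay compound 3 gives > 32500 nM, which is a limit and not a number. Within the data shown here, compound 1 and compound 2 also gave only limits, so no step from either to compound 3 can be read. On these data alone, whether methoxy to hydroxy, or 3,4-dichlorophenyl in place of 3-(trifluoromethyl)phenyl, changes growth inhibition stays open.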